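Azide epimer of a sphingosine-phosphate mimic as lyase inhibitor

The source may report more compounds than this note shows. Statements on the series, on what has been measured and on what is new or still open speak of the compounds shown alone.

Measured compounds:
compound 1, `CCCCCCCCCCCCCCC[C@H](O)[C@H](COP(=O)(O)O)N=[N+]=[N-]`: 16400 nM
compound 2, `CCCCCCCCCCCCC/C=C/[C@@H](O)[C@H](COP(=O)(O)O)NCc1c(COP(=O)(O)O)cnc(C)c1O`: "not determined" (no result reported)

Among the compounds with values here, compound 1 is the only compound with a number in an assay on isolated protein for inhibition of sphingosine-1-phosphate lyase 1 (Homo sapiens), using Lineweaver-Burk analysis; on this read-out higher numbers stand for weaker inhibition and lower numbers for stronger inhibition; for compound 2 this assay gave no result, so nothing can be compared. In this assay compound 1 gives 16400 nM, a weak inhibition.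

Compound 3, `CCCCCCCCCCCCCCC[C@@H](O)[C@H](COP(=O)(O)O)N=[N+]=[N-]`, is the unmeasured partner of compound 1. The change is the two compounds have the same atoms and bonds; at least one stereo element is drawn with a configuration in one of them and without one in the other: 1 of 3 stereo elements differ; a stereocentre at a saturated chain carbon is drawn S in compound 1 and R in compound 3: the same atoms and bonds, with one stereocentre at a saturated chain carbon drawn S in compound 1 and R in compound 3.

Within the data shown here, no measured pair shows the effect of such an inversion, so the direction is unknown. The step from compound 1 to compound 3 is expected to be small, a 1.6-fold lower number from compound 1 to compound 3 (0.21 log units; within the scatter), near the usual scatter. Compound 3 is therefore expected to give about 10000 nM in this assay, within 3000 nM to 40000 nM.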

Compound 3, inhibition constant: 19000 nM
Compound 3: the middle estimate sits 1.9-fold (0.28 log units) below what was measured; the range from low to high includes it.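

Inverting the stereocentre at a saturated chain carbon from S to R gives a 1.2-fold higher number from compound 1 to compound 3 (0.06 log units; within the scatter) in this assay, so this read-out does not separate the two compounds. Within the data shown here, this is the first pair with a number on both sides, and it shows that, for these two azides, the way this one centre is drawn makes no difference beyond the usual scatter. One caution applies when reading this pair: the fact that one of compounds 1 and 3 is drawn with a defined configuration and the other without, at the place where they differ.

As far as these compounds go, whether the other stereo elements matter as little remains open. It is also open whether this centre would stay as unimportant with an amine in place of the azide, or with a longer chain, since the shown pair with numbers carries only the azide and a single chain.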